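Chain extension on the shared core: cytotoxicity notes

The source may report more compounds than this note shows. Statements on the series, on what has been measured and on what is new or still open speak of the compounds shown alone.

compound 1 `CCCCCCc1cc2cn(C3CCC(CO)O3)c(=O)nc2o1` — a functional assay on HEL cells (Homo sapiens); on this read-out lower numbers stand for higher toxicity in this test and higher numbers for lower toxicity in this test: > 143000 nM, a limit of the assay
compound 2 `CCCCCCCCCc1cc2cn(C3CCC(CO)O3)c(=O)nc2o1` — this assay: > 200000 nM, a limit of the assay
compound 3 `CCCCCCCCCCCc1cc2cn(C3CCC(CO)O3)c(=O)nc2o1` — this assay: > 200000 nM, a limit of the assay

Compound 3 stands at a limit in this assay; nothing in the series gives a number, with values sitting at the limit of > 143000 nM in this assay, at which 1 of the 3 values shown sits, and (the limit of > 200000 nM in this assay, at which 2 of the 3 values shown sit). Compound 4 `CCCCCCCCCCCCc1cc2cn(C3CCC(CO)O3)c(=O)nc2o1` differs from compound 3 by methyl in place of hydrogen on a saturated chain carbon, ten or more bonds along the chain from an aromatic carbon. For the measured compounds named here, the steps that bear on this chain growth are a step that the two limits leave unreadable from compound 1 to compound 2, a step that the two limits leave unreadable from compound 1 to compound 3 and a step that the two limits leave unreadable from compound 2 to compound 3, none of them readable in size. No step beyond the scatter is therefore expected for a number no higher from compound 3 to compound 4 (the limit leaves the size open). Compound 4 is expected to give 200000 nM in this assay, with a range from 100000 nM to 400000 nM, most likely again reported only as a limit.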

Compound 4, half-maximal cytotoxic concentration: > 200000 nM
Compound 4 gave a limit, no number; the forecaster's own chance of this, stated with the estimate: 85%; the middle value sits exactly at the limit.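

For the compounds shown here, compound 4 gives only a limit of the assay in this assay, and no step to it from compound 1, compound 2 or compound 3 can be read. The compounds shown leave open where any actual cytotoxic concentration lies along this chain series.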